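The compounds below may be only part of what the source reports. "The series", "measured", "known", "first", "only" and "open" are said of these compounds alone.

Compound 1 `O=C(OC1CCC(CN2CCN(c3cc(=O)c4cc(C(F)(F)F)cc([N+](=O)[O-])c4s3)CC2)CC1)c1ccccc1`: > 64 ug/mL
Compound 2 `O=C(OC1CCC(CN2CCN(c3cc(=O)c4cc(C(F)(F)F)cc([N+](=O)[O-])c4s3)CC2)CC1)c1ccncc1`: > 64 ug/mL

In an ADME assay on Vero cells (Chlorocebus sabaeus) for cytotoxicity, read by MTT assay, with a stated time of 48 h (a higher number here means a weaker inhibitor, a lower number a stronger inhibitor), compound 2 gives > 64 ug/mL, which is a limit of the assay and not a number. Compound 1 gives > 64 ug/mL, which is also a limit. What the data hold so far is the limit of > 64 ug/mL in this assay, at which 2 of the 2 values shown sit, so no real value has yet been seen for this series.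

Compound 3 `Cc1ccc(C(=O)OC2CCC(CN3CCN(c4cc(=O)c5cc(C(F)(F)F)cc([N+](=O)[O-])c5s4)CC3)CC2)cc1` has 4-methylphenyl in place of pyridin-4-yl on a carbonyl carbon. Within the data shown here, the one measured step that bears on this change is a step that the two limits leave unreadable from compound 1 to compound 2, where phenyl gave way to pyridin-4-yl at the same place. It offers no size to carry over, so no step beyond the scatter is expected, and a further limit is the likeliest result.

The expected change is a number no higher from compound 2 to compound 3 (the limit leaves the size open). For compound 3 the estimate is 64 ug/mL, with an expected range of 32 ug/mL to 128 ug/mL.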

Compound 3, half-maximal inhibitory concentration: > 64 ug/mL
Compound 3 gave a limit, no number (the forecaster's own chance of this, stated with the estimate: 85%); the middle value lies on the limit itself.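

Compound 3 also gives a limit and not a number, so the steps linking compound 1, compound 2 and compound 3 in this assay cannot be read: the limit of > 64 ug/mL in this assay, at which 3 of the 3 values shown sit. The compounds shown leave open where a real value for this series lies, and whether pyridin-4-yl, phenyl or 4-methylphenyl on the carbonyl carbon changes it.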